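The source may report more compounds than this note shows. Statements on the series, on what has been measured and on what is new or still open speak of the compounds shown alone.

Among the compounds with values here, in a physicochemical assay for lipophilicity (a higher number here means a more lipophilic compound, a lower number a more polar compound), compound 1 `CCCCC1(c2ccccc2)NC(=O)NC1=O` gives 2.46 and so holds the lower of the two numbers measured so far, while compound 2 `CCCCCCC1(c2ccccc2)NC(=O)NC1=O` gives 3.4 on the same core with a longer chain. Compound 3 `CCCCC1(c2ccccc2C)NC(=O)NC1=O` has not been measured yet. It differs from compound 1 in a single place, with methyl in place of hydrogen on an aromatic carbon is the whole of the change, and the chain stays as it is.

Within the data shown here, only one measured step bears on this. The step of a number 0.94 log units higher from compound 1 to compound 2 (beyond the scatter) is modest and lies beyond the scatter, and there ethyl takes the place of hydrogen on a saturated chain carbon. Among the measured compounds shown here, that is a larger group in a different setting, so it is only a loose guide, and no measured pair here shows a change on the aromatic ring. A smaller rise in this assay is therefore expected, perhaps only just beyond the scatter. The estimated step is a number 0.39 log units higher from compound 1 to compound 3 (beyond the scatter) in the upward direction. The expected value for compound 3 is 2.85 within a range of 2.55 to 3.2 on this scale.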

Compound 3, partition coefficient: 2.96
The estimate for compound 3 lay 0.11 log units below the measured number; low and high end bracket the measured number.
By their numbers in this assay, from the lowest: compound 1; then compound 3; then compound 2.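

In this assay, within the data shown here, the step of a number 0.50 log units higher from compound 1 to compound 3 (beyond the scatter) is the first measured change on the aromatic ring itself, and it shows that methyl in place of hydrogen on an aromatic carbon, ortho to a large group, is enough to move the number beyond the scatter. Among these compounds, until now the only measured step, a number 0.94 log units higher from compound 1 to compound 2 (beyond the scatter), lay on the saturated chain, so a change on the ring could still have vanished in the scatter; instead it runs in the same upward direction as the step on the chain. Nothing measured here explains why the number moves by this amount at this position.

The compounds shown leave open whether methyl on another carbon of the same ring would give a step of similar size, and whether the same change on the longer chain of compound 2 would raise that compound's number in the same way. They also leave open what other groups at this position would do, such as ethyl, a methoxy group, an amine or a carboxylic acid, and so whether the number follows the size of the group or something else about it.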